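The source may report more compounds than this note shows. Statements on the series, on what has been measured and on what is new or still open speak of the compounds shown alone.

Compound 1, `CC(=O)c1nn(-c2ccc(C)cc2)/c(=N/c2nc(-c3c(C)n(C)n(-c4ccccc4)c3=O)cs2)s1`, in a functional assay on A549 cells (Homo sapiens) for cytotoxicity, read by sulforhodamine B assay, with a stated time of 72 h; a lower number here means a stronger inhibitor, a higher number a weaker inhibitor: 20700 nM.
Compound 2, `CCOC(=O)c1nn(-c2ccccc2)/c(=N/c2nc(-c3c(C)n(C)n(-c4ccccc4)c3=O)cs2)s1`, in this assay : > 100000 nM, which is a limit of the assay and not a number.

Compound 2 thus stands at the edge of what the measurement can report; the line the limit of > 100000 nM in this assay, at which 1 of the 2 values shown sits, marks where it sits. Compound 1, carrying an acetyl group and a methylphenyl group, gives a number, but it differs from compound 2 in two places, so no single step can be read between the two. Compound 3, `CCOC(=O)c1nn(-c2ccc(C)cc2)/c(=N/c2nc(-c3c(C)n(C)n(-c4ccccc4)c3=O)cs2)s1`, is not yet measured. It differs from compound 2 by methyl in place of hydrogen on an aromatic carbon. Within the data shown here, with no measured step of this kind available, the expected change in this assay is none beyond the usual scatter, or at most a small gain. Compound 3 is therefore expected to give 80000 nM, with a range from 20000 nM to 200000 nM, and quite possibly again only a limit. The expected step is an at least 1.2-fold lower number from compound 2 to compound 3 (0.09 log units; that floor lies within the scatter).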

Compound 3, half-maximal inhibitory concentration: > 100000 nM
Compound 3: a limit, no number (the forecaster's own chance of this, stated with the estimate: 55%); middle value at least 1.2-fold (0.09 log units) away from the limit.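

Adding methyl to the aromatic ring does not bring compound 2 into the range the assay can report, since compound 3 gives > 100000 nM in this assay, which is again a limit and not a number. The step between these two compounds therefore cannot be read, and any effect of phenyl to 4-methylphenyl stays hidden: the limit of > 100000 nM in this assay, at which 2 of the 3 values shown sit.

Among these compounds, with the 4-methylphenyl group shared, ethoxy in place of methyl on the carbonyl carbon gives an at least 4.8-fold higher number from compound 1 to compound 3 (0.68 log units; beyond the scatter), the first readable single change in this set.

As far as these compounds go, it remains open how a different group on the carbonyl carbon, such as an amine or a longer chain, would read in this assay. From the compounds shown here alone, it is also open whether the 4-methylphenyl group matters at all when methyl sits on the carbonyl carbon, a question that would need the phenyl partner of compound 1.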